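Cytotoxicity notes on the shared-core series

The source may report more compounds than this note shows. Statements on the series, on what has been measured and on what is new or still open speak of the compounds shown alone.

In an ADME assay on HCT-116 cells (Homo sapiens) for cytotoxicity, read by MTT assay (a higher number here means that more compound is tolerated, a lower number that less compound is tolerated), three compounds have been measured so far, and each reading is a limit of the assay rather than a number:
compound 1 `Cc1nc(-c2cccnc2)sc1-c1nnc(Cc2ccccc2)o1` gives > 100 ug/mL
compound 2 `COc1ccccc1-c1nnc(-c2sc(-c3cccnc3)nc2C)o1` gives > 100 ug/mL
compound 3 `Cc1nc(-c2cccnc2)sc1-c1nnc(-c2ccc(Cl)cc2)o1` gives > 100 ug/mL

Compound 3 thus stands at the limit shared by all three readings (the limit of > 100 ug/mL in this assay, at which 3 of the 3 values shown sit). Among the measured compounds shown here, none of the measured steps can be read, since a step that the two limits leave unreadable from compound 1 to compound 3 and a step that the two limits leave unreadable from compound 2 to compound 3 fall between two limits, as does a step that the two limits leave unreadable from compound 1 to compound 2. Compound 4 `Cc1cccc(-c2nnc(-c3sc(-c4cccnc4)nc3C)o2)c1` differs from compound 3 by 3-methylphenyl in place of 4-chlorophenyl on an aromatic carbon. No readable step bears on this change, so no step beyond the scatter is expected in this assay. Compound 4 is therefore expected to remain at the limit, an expected step of a number no higher from compound 3 to compound 4 (the limit leaves the size open). Compound 4 is estimated at 100 ug/mL, with a range from 50 ug/mL to 200 ug/mL.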

Compound 4, half-maximal cytotoxic concentration: > 100 ug/mL
Compound 4 was reported as a limit; the forecaster's own chance of this, stated with the estimate: 85%; the middle value lies on the limit itself.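

The steps from compound 1, compound 2 and compound 3 to compound 4 cannot be read, as all four readings are limits: the limit of > 100 ug/mL in this assay, at which 4 of the 4 values shown sit.

The compounds shown leave open whether any group on the shared core would bring a reading off this limit.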